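The source may hold more compounds than are shown below. What is called first, only, known or untested is meant among the compounds shown, and "the series" means these compounds.

- compound 1 `O=[N+]([O-])c1cccc(Cn2cc(CO)c3ccccc32)c1`: 39 nM
- compound 2 `OCCc1cn(Cc2ccc(Cl)cc2)c2ccccc12`: > 31600 nM

In a functional assay on NCI-H460 cells (Homo sapiens) for cytotoxicity, read by sulforhodamine B assay, with a stated time of 3 days (on this read-out higher numbers stand for weaker inhibition and lower numbers for stronger inhibition), compound 1 gives 39 nM. Compound 2 gives no number, only a limit, and stands at the limit of > 31600 nM in this assay, at which 1 of the 2 values shown sits.

Compound 3 `COC(=O)CNCc1cn(Cc2ccc(Cl)cc2)c2ccccc12` keeps the shared core of compound 2 and differs in one side chain: ((methoxycarbonyl)methyl)amino in place of hydroxymethyl on a saturated chain carbon bound to an aromatic carbon. In words, ((methoxycarbonyl)methyl)amino takes the place of hydroxymethyl on a saturated chain carbon bound to an aromatic carbon.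

Among the compounds with values here, no step between measured compounds gives a size for this change, so the expectation is loose. It starts from compound 2, whose > 31600 nM is a limit. A modest move toward stronger inhibition is expected, and compound 3 may well stay at the limit too. The expected change is an at least 2.1-fold lower number from compound 2 to compound 3 (0.32 log units; beyond the scatter). For compound 3 the estimate is 15000 nM, with an expected range of 3000 nM to 31600 nM.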

Compound 3, half-maximal inhibitory concentration: 100 nM
Beside the measured number, compound 3's estimate is 150-fold (2.18 log units) above it, and the stated range ends above it.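

On a saturated chain carbon bound to an aromatic carbon, ((methoxycarbonyl)methyl)amino in place of hydroxymethyl gives, in this assay, an at least 310-fold lower number from compound 2 to compound 3 (2.49 log units; beyond the scatter), a large step beyond the scatter. Compound 2 is held only by a limit, so the full size of this step cannot be given: the limit of > 31600 nM in this assay, at which 1 of the 3 values shown sits. Within the data shown here, the earlier compounds gave no step at all, and this one is the first to show that a change of side chain at this place alone can move the read-out from a limit to a measured value.

Which part of the ((methoxycarbonyl)methyl)amino group carries the step stays open. Whether a simple amine, a carboxylic acid in place of the methyl ester or a longer chain at this place would give a step of like size also remains unanswered.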